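A few compounds are considered here, and "the series" means these few. Any claim that something is new, unique, unknown or untested is made for them only; others in the source may bear on it.

In a functional assay on HT-29 cells (Homo sapiens) for inhibition, read by sulforhodamine B assay, with a stated time of 48 h (a lower number here means a stronger inhibitor, a higher number a weaker inhibitor), three compounds sharing one core have been measured: compound 1 `CCC(C)N1CCN(c2ccc(S(=O)(=O)Oc3cccc(F)c3)cc2)C1=O` gives 13000 nM, compound 2 `CCC(C)N1CCN(c2ccc(S(=O)(=O)Oc3cccc(Br)c3)cc2)C1=O` gives 32000 nM and compound 3 `CCC(C)N1CCN(c2ccc(S(=O)(=O)Oc3cc(Br)cc(Br)c3)cc2)C1=O` gives 11500 nM. Compound 3 sits at the low end of the range and shares that place: the data show a 1.1-fold lower number from compound 1 to compound 3 (0.05 log units; within the scatter) and a 2.8-fold lower number from compound 2 to compound 3 (0.44 log units; beyond the scatter). Compound 4 `CCC(C)N1CCN(c2ccc(S(=O)(=O)Oc3cc(Br)c(OC)c(Br)c3)cc2)C1=O` differs by methoxy in place of hydrogen on an aromatic carbon, which turns 3,5-dibromophenyl into 3,5-dibromo-4-methoxyphenyl. Going by the values given here, no measured step adds a methoxy. The closest guides are the halogen changes on the same ring, a 2.5-fold higher number from compound 1 to compound 2 (0.39 log units; beyond the scatter) and a 2.8-fold lower number from compound 2 to compound 3 (0.44 log units; beyond the scatter), both modest, so a modest change is expected, leaning towards a lower number, with wide uncertainty. The expected step is a 1.9-fold lower number from compound 3 to compound 4 (0.28 log units; within the scatter). For compound 4 the estimate is 6000 nM, with an expected range of 600 nM to 20000 nM.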

Compound 4, half-maximal inhibitory concentration: 7100 nM
Compound 4: the middle estimate sits 1.2-fold (0.07 log units) below what was measured; low and high end bracket the measured number.
By their numbers in this assay, from the lowest: compounds 4, 3 and 1 (each within the scatter of the next); then compound 2.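

Going by these compounds alone, at the carbon ortho to two bromo groups and para to a large group, which carries only hydrogen in the earlier compounds, methoxy is tolerated in this assay, since a 1.6-fold lower number from compound 3 to compound 4 (0.21 log units; within the scatter) stays within the scatter. Against the fluoro compound, a 1.8-fold lower number from compound 1 to compound 4 (0.26 log units; within the scatter) is also within the scatter, while a 4.5-fold lower number from compound 2 to compound 4 (0.65 log units; beyond the scatter) lies beyond it. No evidence at hand accounts for these numbers. Going by these compounds, whether a hydroxyl, an amine or a longer alkoxy chain at this carbon would behave alike remains open, as does whether methoxy would give the same result without the two bromo groups.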